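Ethoxy to propoxy in a series at its limit

The source may report more compounds than this note shows. Statements on the series, on what has been measured and on what is new or still open speak of the compounds shown alone.

- compound 1 `COc1cc(OC)c2c(c1)C(C(O)c1ccc(O)cc1)OC2=O` gives > 10000 nM
- compound 2 `COc1ccc(C(O)C2OC(=O)c3c(OC)cc(OC)cc32)cc1` gives > 10000 nM
- compound 3 `CCOc1ccc(C(O)C2OC(=O)c3c(OC)cc(OC)cc32)cc1` gives > 10000 nM

In a functional assay on RAW264.7 cells (Mus musculus) for inhibition, read by Griess assay, with stated times of 1 h and 24 h (a higher number here means a weaker inhibitor, a lower number a stronger inhibitor), compound 3 stands at > 10000 nM, which is a limit and not a number. The series offers no number to compare it with: the limit of > 10000 nM in this assay, at which 3 of the 3 values shown sit. Compound 4 `CCCOc1ccc(C(O)C2OC(=O)c3c(OC)cc(OC)cc32)cc1` takes ethoxy to propoxy: methyl in place of hydrogen on a saturated chain carbon, two bonds along the chain from an oxygen on an aromatic ring. The closest measured change is a step that the two limits leave unreadable from compound 2 to compound 3, while a step that the two limits leave unreadable from compound 1 to compound 2 and a step that the two limits leave unreadable from compound 1 to compound 3 also bear on it. None of these steps has a readable size, so no direction is expected and no change beyond the scatter. The expected step is a step that the limit leaves unreadable from compound 3 to compound 4. For compound 4 the estimate is 15000 nM, with an expected range from 7000 nM to 40000 nM.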

Compound 4, half-maximal inhibitory concentration: 9260 nM
Compound 4: middle estimate off by 1.6-fold (0.21 log units), on the high side, and the stated range covers the measured number.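

Compound 4 is the only compound shown that carries a number, and the others stand at a limit: the limit of > 10000 nM in this assay, at which 3 of the 4 values shown sit.
Against those limits, the change to propoxy gives an at least 1.0-fold lower number from compound 3 to compound 4 (0.03 log units; that floor lies within the scatter), and the wider changes at this place give an at least 1.0-fold lower number from compound 2 to compound 4 (0.03 log units; that floor lies within the scatter) and an at least 1.0-fold lower number from compound 1 to compound 4 (0.03 log units; that floor lies within the scatter). As far as these compounds go, these are floors, so the true size of each step is unknown, and the steps among the three earlier compounds cannot be read.

Still open, from the compounds shown here alone, is how a butoxy group, a longer chain or an amine in place of the propoxy group would read in this assay.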